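The compounds below may be only part of what the source reports. "The series", "measured", "known", "first", "only" and "open" are said of these compounds alone.

Measured so far in this series:
compound 1 `COc1ccc(NC(=O)Nc2cc(C)nc3ccccc23)cc1F`: 26000 nM
compound 2 `Cc1cc(NC(=O)Nc2ccc(F)cc2)c2ccccc2n1`: > 25000 nM

In an ADME assay on BJ cells (Homo sapiens) for cytotoxicity, with a stated time of 72 h (on this read-out lower numbers stand for an effect already at smaller amounts and higher numbers for an effect only at larger amounts of compound), compound 1 gives 26000 nM. For compound 2 the reported figure of > 25000 nM is a limit of the assay and not a number. Compound 2 thus stands at the limit of > 25000 nM in this assay, at which 1 of the 2 values shown sits, the top end of what this assay resolves, with compound 1 close to it on the numbers given. Compound 3 `Cc1cc(NC(=O)Nc2ccc(F)c(F)c2)c2ccccc2n1` is not yet measured in this assay. It differs from compound 2 by fluoro in place of hydrogen on an aromatic carbon. Going by the values given here, no measured pair shows a step of this kind, so no size can be read off from the series. The expected step in this assay is none beyond the scatter, and the step is estimated as a step that the limit leaves unreadable from compound 2 to compound 3. For compound 3 the value in this assay is estimated at 30000 nM, in a range from 14000 nM to 65000 nM, and most probably it will again be reported only as a limit.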

Compound 3, half-maximal effective concentration: > 25000 nM
Compound 3 was reported as a limit (the forecaster's own chance of this, stated with the estimate: 65%); the middle value is on the limit's open side.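

In this assay no step can be read among compound 1, compound 2 and compound 3, because the results for compound 2 and compound 3 are limits of the assay and not numbers: the limit of > 25000 nM in this assay, at which 2 of the 3 values shown sit.

The compounds shown leave open whether fluoro in place of hydrogen on an aromatic carbon changes this read-out at all.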